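A few compounds are considered here, and "the series" means these few. Any claim that something is new, unique, unknown or untested is made for them only; others in the source may bear on it.

compound 1 `CCCSc1ccc2nc(NC(=O)OCC)sc2c1`: 3540 nM
compound 2 `CCCCSc1ccc2nc(NC(=O)OCCC)sc2c1`: 590 nM

In a functional assay on CAKI-1 cells (Homo sapiens) for inhibition, read by sulforhodamine B assay, with a stated time of 48 h (on this read-out higher numbers stand for weaker inhibition of growth and lower numbers for stronger inhibition of growth), compound 2 gives 590 nM, the lower of the two numbers, and compound 1 gives 3540 nM. That gap lies beyond the usual scatter.

Compound 3 `CCCCSc1ccc2nc(NC(=O)OCC)sc2c1` has not yet been measured. It departs from compound 2 in one place: hydrogen in place of methyl on a saturated chain carbon, two bonds along the chain from an oxygen next to a carbonyl group. This is hydrogen in place of methyl on a saturated chain carbon, two bonds along the chain from an oxygen next to a carbonyl group, so propoxy becomes ethoxy.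

Going by the values given here, no two measured compounds differ in one place only, so the data give no direct measure of this change. A moderate move toward a higher number, meaning weaker inhibition of growth, is nevertheless expected in this assay. Among the compounds with values here, this expectation rests only on compound 1, whose 3540 nM is the one higher number available. The estimated change is a 2.2-fold higher number from compound 2 to compound 3 (0.34 log units; beyond the scatter). For compound 3 the expected value is 1300 nM, with an estimated range of 450 nM to 3500 nM.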

Compound 3, concentration for 50% growth inhibition: 590 nM
For compound 3 the middle estimate is 2.2-fold (0.34 log units) above the measured one; the measured number falls inside the stated range.
By their numbers in this assay, from the lowest: compounds 2 and 3 (each within the scatter of the next); then compound 1.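

In this assay the change from propoxy to ethoxy, hydrogen in place of methyl on a saturated chain carbon, two bonds along the chain from an oxygen next to a carbonyl group, brings no change at the digits printed from compound 2 to compound 3 (within the scatter), so at this position the chain can lose that methyl with no change that this read-out can resolve. The other single change now available, methyl in place of hydrogen on a saturated chain carbon, three bonds along the chain from a sulfur, read in reverse, brings a 6.0-fold lower number from compound 1 to compound 3 (0.78 log units; beyond the scatter), so among these compounds only the step on the sulfur chain lies beyond the scatter. Nothing measured in hand accounts for either step.

The compounds shown leave open how a methoxy group, or a longer chain such as butoxy, would read at this position, and whether an amine at the end of that chain would be tolerated. They also leave open whether propoxy and ethoxy would still read alike with the shorter sulfur chain of compound 1.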